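From 1H-imidazol-1-yl to dimethylamino on the propyl chain

The source may hold more compounds than are shown below. What is called first, only, known or untested is meant among the compounds shown, and "the series" means these compounds.

Three compounds on a shared core have numbers in a functional assay on K562 cells (Homo sapiens) for antiproliferative activity, read by MTT assay, with a stated time of 48 h; a lower number here means a stronger inhibitor, a higher number a weaker inhibitor. Compound 1 `Cn1cc(C2=C(c3nn(CCCN4CCCCC4)c4ncccc34)C(=O)N(c3ccccc3)C2=O)c2ccccc21` gives 3790 nM. Compound 2 `Cn1cc(C2=C(c3nn(CCn4ccnc4)c4ncccc34)C(=O)N(c3ccccc3)C2=O)c2ccccc21` gives 26400 nM. Compound 3 `Cn1cc(C2=C(c3nn(CCCn4ccnc4)c4ncccc34)C(=O)N(c3ccccc3)C2=O)c2ccccc21` gives 5510 nM.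

Compound 3 sits with compound 1 rather than with compound 2: the first pair is separated by a 1.5-fold higher number from compound 1 to compound 3 (0.16 log units; within the scatter), whereas the other comparison shows a 4.8-fold lower number from compound 2 to compound 3 (0.68 log units; beyond the scatter).

For the measured compounds named here, compound 4 `CN(C)CCCn1nc(C2=C(c3cn(C)c4ccccc34)C(=O)N(c3ccccc3)C2=O)c2cccnc21` has no measurement yet. It keeps the core of compound 3 and changes one group: dimethylamino in place of 1H-imidazol-1-yl on a saturated chain carbon, three bonds along the chain from an aromatic nitrogen. The change reads as 3-(1H-imidazol-1-yl)propyl to 3-(dimethylamino)propyl.

Going by the values given here, the nearest precedent is the exchange of piperidin-1-yl and 1H-imidazol-1-yl at the same place, a 1.5-fold higher number from compound 1 to compound 3 (0.16 log units; within the scatter). The larger steps, a 7.0-fold higher number from compound 1 to compound 2 (0.84 log units; beyond the scatter) and a 4.8-fold lower number from compound 2 to compound 3 (0.68 log units; beyond the scatter), both involve a change in chain length, and compound 4 has no such change. Among the compounds with values here, no measured compound carries dimethylamino, so this expectation rests on a single comparison and the range stays wide.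

No step beyond the scatter is therefore expected in this assay. The expected move is a 1.2-fold lower number from compound 3 to compound 4 (0.09 log units; within the scatter). For compound 4 the estimated value is 4500 nM, within an expected range of 1800 nM to 11000 nM.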

Compound 4, half-maximal inhibitory concentration: 1700 nM
The estimate for compound 4 lay 2.6-fold (0.42 log units) above the measured number; the whole stated range lies above it.
By their numbers in this assay, from the lowest: compound 4; then compounds 1 and 3 (each within the scatter of the next); then compound 2.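

On the 3-(1H-imidazol-1-yl)propyl to 3-(dimethylamino)propyl change, the group at the end of the chain now matters in this assay (a 3.2-fold lower number from compound 3 to compound 4 (0.51 log units; beyond the scatter)), whereas the earlier exchange of piperidin-1-yl for 1H-imidazol-1-yl at the same place stayed within the scatter (a 1.5-fold higher number from compound 1 to compound 3 (0.16 log units; within the scatter)). Dimethylamino, the only one of these end groups with no ring, also separates from piperidin-1-yl (a 2.2-fold lower number from compound 1 to compound 4 (0.35 log units; beyond the scatter)), so at this place two groups that could not be told apart both give way to a smaller one, and compound 4 is the strongest inhibitor of the four. The widest gap in the series (a 16-fold lower number from compound 2 to compound 4 (1.19 log units; beyond the scatter)) joins this end-group change to the chain-length change, so it cannot be credited to either alone.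

Still open, from the compounds shown here alone, is whether diethylamino, pyrrolidin-1-yl or morpholin-4-yl on the same propyl chain would match compound 4, and whether 2-(dimethylamino)ethyl or 4-(dimethylamino)butyl would keep its number. No measurement available here accounts for the difference between these end groups.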